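Aryl-amine variation on the shared core: notes toward compound 4

The compounds below may be only part of what the source reports. "The series", "measured", "known", "first", "only" and "open" are said of these compounds alone.

Values in a functional assay on HeLa cells (Homo sapiens) for antiproliferative activity, read by spectrophotometry, with a stated time of 2 days; a higher number here means a weaker inhibitor of growth, a lower number a stronger inhibitor of growth:
- compound 1 `COc1ccc(Nc2ncc(C(F)(F)F)c(N3Cc4cccc(N(C)S(C)(=O)=O)c4C3)n2)cc1C(F)(F)F`: 14000 nM
- compound 2 `CN(c1cccc2c1CN(c1nc(Nc3cc(C(F)(F)F)cc(C(F)(F)F)c3)ncc1C(F)(F)F)C2)S(C)(=O)=O`: 9200 nM
- compound 3 `Cc1cc(Cl)ccc1Nc1ncc(C(F)(F)F)c(N2Cc3cccc(N(C)S(C)(=O)=O)c3C2)n1`: 17400 nM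

Compound 1 sits in the middle of the three numbers. Compound 3 is its nearest neighbour, with a 1.2-fold higher number from compound 1 to compound 3 (0.09 log units; within the scatter). Compound 2 gives 9200 nM, and the gap between compound 2 and compound 1 also lies within the usual scatter, so no ordering among the three is supported.

Compound 4 `CN(c1cccc2c1CN(c1nc(Nc3ccc(C(F)(F)F)cc3)ncc1C(F)(F)F)C2)S(C)(=O)=O` is not yet measured. It differs from compound 1 in one place: 4-(trifluoromethyl)phenyl in place of 4-methoxy-3-(trifluoromethyl)phenyl on a nitrogen on an aromatic ring. Among the measured compounds shown here, the only measured step that bears on this is the one from compound 1 to compound 3, a swap of the aryl group on the same nitrogen, which stayed within the scatter (a 1.2-fold higher number from compound 1 to compound 3 (0.09 log units; within the scatter)). The two values of compound 1 and compound 2, another such aryl swap, likewise sit within the scatter of each other. Three aryl variants on this nitrogen have all given numbers close together, so no step beyond the scatter is expected in this assay for compound 4, in either direction.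

Compound 4 is therefore estimated at 13000 nM, with a range of 5500 nM to 31000 nM. The expected step from compound 1 is a 1.1-fold lower number from compound 1 to compound 4 (0.03 log units; within the scatter).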

Compound 4, concentration for 50% growth inhibition: > 30000 nM
Compound 4: no number, only a limit; the forecaster's own chance of this, stated with the estimate: 10%; at least 2.3-fold (0.36 log units) between middle value and limit.
By their numbers in this assay, from the lowest: compounds 2, 1 and 3 (each within the scatter of the next). At a limit, above all of these: compound 4.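

In this assay compound 4 gives > 30000 nM, which is a limit of the assay and not a number, and it is the only such limit in the set: the limit of > 30000 nM in this assay, at which 1 of the 4 values shown sits. Even as a floor, the reading is an at least 2.1-fold higher number from compound 1 to compound 4 (0.33 log units; beyond the scatter), the only step shown on this nitrogen that lies beyond the scatter, so this position is less tolerant of change than the earlier aryl swaps suggested, as a 1.2-fold higher number from compound 1 to compound 3 (0.09 log units; within the scatter) stayed within it. Among the compounds shown here, the comparison with the other aryl variant is weaker, with an at least 1.7-fold higher number from compound 3 to compound 4 (0.23 log units; that floor lies within the scatter), so no order between that pair is supported, and the sensitivity seen here rests on the single change from 4-methoxy-3-(trifluoromethyl)phenyl to 4-(trifluoromethyl)phenyl.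

That change removes the methoxy and alters where the trifluoromethyl stands in one move, so the compounds shown do not separate the two, and the true size of the step stays unknown while compound 4 has only a limit. Also open, on these data alone, is how an aryl group carrying an amine or a carboxylic acid on this nitrogen would read in this assay.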